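Swapping a Bromophenyl for a Cyclohexyl on a Shared Core

A few compounds are considered here, and "the series" means these few. Any claim that something is new, unique, unknown or untested is made for them only; others in the source may bear on it.

Of the compounds shown here, three sharing one core have been tested in an ADME assay on MDBK cells (Bos taurus) for cytotoxicity; a lower number here means that less compound is tolerated, a higher number that more compound is tolerated. Compound 1 `Cc1cccc(Cn2ccc3nc(-c4ccccc4)nc-3c2)c1` gives > 100000 nM, which is a limit of the assay rather than a number. Compound 2 `Fc1cccc(Cn2ccc3nc(-c4ccccc4)nc-3c2)c1` likewise gives > 100000 nM, again a limit. Going by the values given here, compound 3 `Brc1cccc(Cn2ccc3nc(-c4ccccc4)nc-3c2)c1` gives 85000 nM, the only plain number in the set. Two of the three values sit at the limit of > 100000 nM in this assay, at which 2 of the 3 values shown sit. Among the measured steps, an at least 1.1-fold lower number from compound 1 to compound 3 (0.07 log units; that floor lies within the scatter) and an at least 1.1-fold lower number from compound 2 to compound 3 (0.07 log units; that floor lies within the scatter) each amount only to a floor that lies within the scatter, and the remaining step is a step that the two limits leave unreadable from compound 1 to compound 2.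

Compound 4 `c1ccc(-c2nc3ccn(CC4CCCCC4)cc-3n2)cc1` has not yet been measured. Its change from compound 3 is cyclohexyl in place of 3-bromophenyl on a saturated chain carbon bound to an aromatic nitrogen. Where the three measured compounds differ from one another only by the group on an aromatic carbon, compound 4 replaces the whole 3-bromophenyl with a cyclohexyl on the saturated chain carbon bound to an aromatic nitrogen, a change no measured step covers.

Among the compounds with values here, since none of the measured steps moved the number beyond the scatter, no step beyond the scatter is expected here either; the estimated step is a 1.1-fold higher number from compound 3 to compound 4 (0.02 log units; within the scatter). Compound 4 is therefore expected to give about 90000 nM, within 40000 nM to 200000 nM, with a real chance that the assay reports only a limit.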

Compound 4, half-maximal cytotoxic concentration: > 100000 nM
Compound 4 ended at the assay's limit; the forecaster's own chance of this, stated with the estimate: 55%; at least 1.1-fold (0.04 log units) between middle value and limit.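

This is the first change shown at the saturated chain carbon bound to an aromatic nitrogen, and it exchanges a whole ring rather than one group on a ring: in this assay compound 4 gives > 100000 nM, which is a limit of the assay and not a number. Going by these compounds alone, the one readable step is an at least 1.1-fold higher number from compound 3 to compound 4 (0.07 log units; that floor lies within the scatter), so an aromatic ring at this place is not needed to keep the number this high, although the size of the step remains hidden. The steps to compound 4 from compound 1 and from compound 2 cannot be read, and the set now gathers at a single ceiling: the limit of > 100000 nM in this assay, at which 3 of the 4 values shown sit.

The compounds shown leave open how much of each compound at the limit the cells actually tolerate, so any real difference among those compounds stays hidden. They also leave open whether an amine, a carboxylic acid or a longer chain in place of the cyclohexyl would stay at the limit or give a number that can be read.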